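The source may hold more compounds than are shown below. What is called first, only, known or untested is meant among the compounds shown, and "the series" means these compounds.

Compound 1 `Nc1nc(Cl)c2ncn(Cc3ccccc3CCl)c2n1` — 87100 nM
Compound 2 `ClCc1cccc(Cn2cnc3nc(Cl)nc(Cl)c32)c1` — > 100000 nM
Compound 3 `Nc1nc(Cl)c2ncn(Cc3cccc(CCl)c3)c2n1` — 53700 nM

In a functional assay on MCF7 cells (Homo sapiens) for cytotoxicity, read by sulforhodamine B assay, with a stated time of 48 h (a lower number here means that less compound is tolerated, a higher number that more compound is tolerated), compound 1 gives 87100 nM and compound 3 gives 53700 nM, the two numbers lying within the usual scatter of each other. For compound 2 the result is only a limit of the assay, > 100000 nM, so no number stands for it. Among the three results, compound 2 is the one that sits at the limit of > 100000 nM in this assay, at which 1 of the 3 values shown sits.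

Compound 4 `ClCc1cccc(Cn2cnc3ncnc(Cl)c32)c1` has not yet been measured in this assay . It differs from compound 2 in one place: hydrogen in place of chloro on an aromatic carbon. Because compound 2 gives only > 100000 nM, the step from compound 2 to compound 4 cannot be sized from what is known. Compound 1 and compound 3, which carry a different group at that same position, are both tolerated at high concentration, and nothing in these data points compound 4 away from that region. The step of a number no higher from compound 2 to compound 4 (the limit leaves the size open) is therefore expected to be none beyond the scatter, and a limit is again a likely outcome. Compound 4 is expected to come out near 100000 nM, within a range from 40000 nM to 300000 nM.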

Compound 4, concentration lethal to 50% of the cells: 39000 nM
The estimate for compound 4 lay 2.6-fold (0.41 log units) above the measured number; measured number below the stated range.
By their numbers in this assay, from the lowest: compounds 4, 3 and 1 (each within the scatter of the next, the first and the last beyond it). At a limit, above all of these: compound 2.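

In this assay, for the compounds shown here, the position between two ring nitrogen atoms now carries a step that can be read, where the earlier compounds gave none: hydrogen in place of chloro gives an at least 2.5-fold lower number from compound 2 to compound 4 (0.40 log units; beyond the scatter). This is a minimum size, and it shows that, on this core, the chloro group at this position cannot be exchanged for hydrogen without a change in the number, while compound 4 falls in the same region as compound 3, whose group at this position is different. Compound 2 itself remains a limit of the assay and not a number: the limit of > 100000 nM in this assay, at which 1 of the 4 values shown sits.

The compounds shown leave open how large the step really is, and why removing the chloro group lowers the number. They also leave open where a methyl group, a methoxy group or a fluoro group at this position would fall.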